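This account rests on a few compounds, and the source may have more. Where it says the series, first, only, none or still open, it means among the compounds named here.

Series notes, cytotoxicity on endothelial cells

Measured in a functional assay on EA.hy 926 cells (Homo sapiens) for cytotoxicity, read by MTT assay, with stated times of 24 h and 12 h, tested at 50 uM; a lower number here means a weaker effect, a higher number a stronger effect of the compound at the concentration tested:
- compound 1 `Cc1nc(C)c(C(=O)Oc2ccccc2/C=C/C(=O)O)nc1C`: 64.9%
- compound 2 `CCOC(=O)/C=C/c1ccc(OC(=O)c2nc(C)c(C)nc2C)c(O)c1`: 211%
- compound 3 `CCOC(=O)/C=C/c1cc(OC)c(OC(=O)c2nc(C)c(C)nc2C)c(OC)c1`: -13.6%

Compound 2 stands highest of the three numbers in this assay. Its nearest neighbour is compound 1, whose number is lower by a margin beyond the scatter, and compound 3 lies furthest away, again beyond the scatter. No pair among these three differs in only one place, so no single-point step is available from the measured set; the gaps merely show that the three esters of the shared core span a wide band in this read-out.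

Compound 4 `CCOC(=O)/C=C/c1ccc(OC(=O)c2nc(C)c(C)nc2C)cc1` is the next member. It differs from compound 2 as follows: hydrogen in place of hydroxy on an aromatic carbon. For the measured compounds named here, no measured pair isolates this change, so its size in this assay cannot be read from the data. Given that compound 2 gives 211% while the other two members of the series sit far lower, the expectation is that removing the hydroxy moves compound 4 downward, by a step beyond the scatter, toward the region occupied by compound 1 and compound 3. The step from compound 2 to compound 4 is expected to be a number 141 percentage points lower from compound 2 to compound 4 (beyond the scatter). For compound 4 in this assay the estimate is 70%, with a range from 0% to 180%.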

Compound 4, a percentage reported as activity, at one concentration (the size of the read-out at that concentration, not a potency): 62.6%
The estimate for compound 4 lay 7.4 percentage points above the measured number, and the stated range covers the measured number.
By their numbers in this assay, from the lowest: compound 3; then compounds 4 and 1 (each within the scatter of the next); then compound 2.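

In this assay, the hydroxy on the aromatic carbon, ortho to a large group and meta to the 2-(ethoxycarbonyl)ethenyl group, now has a measured single-point step: putting hydrogen in its place gives a number 148.4 percentage points lower from compound 2 to compound 4 (beyond the scatter). For the compounds shown here, this is the first pair that differs in one place, so the high reading of compound 2 at 211% can now be tied to this one substituent rather than only seen as a gap between compounds that differ in several places. The step is large, which marks this carbon as a sensitive point in this read-out, at least within the ethyl ester scaffold shared by this pair.

Nothing available bears on the reason this single change has so large an effect. From the compounds shown here alone, it remains open whether an amine or a fluorine on the same carbon would keep the reading of compound 2 or that of compound 4, and whether the step would hold if the ethyl ester were replaced by a longer chain such as a butyl ester.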